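Methoxy to Chloro on the Phenylpiperazine: Cytotoxicity Outlook

The source may report more compounds than this note shows. Statements on the series, on what has been measured and on what is new or still open speak of the compounds shown alone.

Compound 1 `COc1ccc(-c2nnc(N3CCN(C(=O)CN4CCN(c5ccccc5OC)CC4)CC3)nc2-c2ccc(OC)cc2)cc1` and compound 2 `COc1ccc(-c2nnc(N3CCN(C(=O)CN4CCN(c5ccccc5Cl)CC4)CC3)nc2-c2ccc(OC)cc2)cc1` share one core; compound 3 `COc1cccc(N2CCN(CC(=O)N3CCN(c4nnc(-c5ccc(Cl)cc5)c(-c5ccc(Cl)cc5)n4)CC3)CC2)c1` and compound 4 `O=C(CN1CCN(c2cccc(Cl)c2)CC1)N1CCN(c2nnc(-c3ccc(Cl)cc3)c(-c3ccc(Cl)cc3)n2)CC1` share another, and the difference between the two cores is not broken down here. In an ADME assay on NIH3T3 cells (Mus musculus) for cytotoxicity, read by MTT assay, with a stated time of 24 h (a higher number here means a weaker inhibitor, a lower number a stronger inhibitor), compound 1 reaches only a limit, > 821000 nM. In this assay compound 2 likewise reaches only a limit, > 814000 nM. The change from compound 1 to compound 2 is chloro in place of methoxy on an aromatic carbon, and its step is a step that the two limits leave unreadable from compound 1 to compound 2. From compound 3 to compound 4 the change is chloro in place of methoxy on an aromatic carbon, the same kind of change, though the place differs: ortho to a large group in the first pair, meta to a large group in the second. In this assay compound 3 gives 202000 nM. Since the step that the two limits leave unreadable from compound 1 to compound 2 cannot be read, the step from compound 3 to compound 4 is expected to be small, a 1.2-fold higher number from compound 3 to compound 4 (0.09 log units; within the scatter). Compound 4 is thus estimated at 250000 nM, between 100000 nM and 700000 nM.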

Compound 4, half-maximal inhibitory concentration: > 803000 nM
Compound 4 ended at the assay's limit; the forecaster's own chance of this, stated with the estimate: 30%; middle value at least 3.2-fold (0.50 log units) from the limit.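

In this assay, chloro in place of methoxy gives an at least 3.9-fold higher number from compound 3 to compound 4 (0.59 log units; beyond the scatter), so in this core the change raises the number beyond the usual scatter. Compound 4 reaches only a limit of the assay, > 803000 nM, so this step has a floor but no measured size. Going by these compounds, the same change in the other core, from compound 1 to compound 2, cannot be read, and its place on the ring differs, so whether the step carries from one core to the other remains unknown.

The compounds shown leave open how an amine or a carboxylic acid in that place would read in this assay. They also leave open the size of the methoxy-to-chloro step in a pair where both values are true numbers.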